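Removing the dimethylcarbamoyl from the pyrazole of compound 2

The source may report more compounds than this note shows. Statements on the series, on what has been measured and on what is new or still open speak of the compounds shown alone.

Measured so far:
compound 1 `O=C(O)CCNC(=O)c1ccc(C(Oc2ccc(-n3cc(C(F)(F)F)cn3)cc2)C2CC2)cc1`, 15000 nM
compound 2 `CCCC(Oc1ccc(-n2cc(C(=O)N(C)C)cn2)cc1)c1ccc(C(=O)NCCC(=O)O)cc1`, > 30000 nM
compound 3 `O=C(O)CCNC(=O)c1ccc(C(Oc2ccc(-n3cc(C(F)(F)F)cn3)cc2)C2CCCC2)cc1`, 4000 nM

In a functional assay on cells for antagonist activity at Glucagon receptor (Homo sapiens), read by cAMP accumulation, in the presence of a further agent that is not named here (on this read-out higher numbers stand for weaker inhibition and lower numbers for stronger inhibition), compound 2 gives only a limit, > 30000 nM, and the limit of > 30000 nM in this assay, at which 1 of the 3 values shown sits, is where it sits among the three values shown. Compound 4 `CCCC(Oc1ccc(-n2cccn2)cc1)c1ccc(C(=O)NCCC(=O)O)cc1` differs from compound 2 by hydrogen in place of dimethylcarbamoyl on an aromatic carbon. Among the compounds with values here, the only measured step, a 3.8-fold lower number from compound 1 to compound 3 (0.57 log units; beyond the scatter), changes a different part of the shared core and so does not speak to this change. With no guidance on this place, compound 4 is expected to stay near the limit, and the expected step is a number no higher from compound 2 to compound 4 (the limit leaves the size open). Compound 4 is estimated at 30000 nM, with a range from 8000 nM to 100000 nM, with a fair chance that only a limit is reported again.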

Compound 4, antagonist equilibrium constant: > 55000 nM
Compound 4: no number, only a limit (the forecaster's own chance of this, stated with the estimate: 50%); middle value at least 1.8-fold (0.26 log units) away from the limit.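

Within the data shown here, compound 2 and compound 4 each give only a limit of the assay, and no step between them can be read. As far as these compounds go, whether hydrogen in place of dimethylcarbamoyl changes the inhibition at all, and in which direction, stays open.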